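A few compounds are considered here, and "the series" means these few. Any claim that something is new, unique, unknown or untested is made for them only; others in the source may bear on it.

The account concerns a small set of compounds built on one shared core and tested in an assay on A549 cells with Cystic fibrosis transmembrane conductance regulator variant F508del (Homo sapiens) as the target, read by fluorescence, with a stated time of 25 min; on this read-out higher numbers stand for larger maximal responses and lower numbers for smaller maximal responses. Within the data shown here, compound 1 `NC(=O)C1CCN(c2nc(-c3ccccn3)nc3c2CN(Cc2ccccc2)CC3)CC1` gives 34.4% in this assay, and compound 3 `CN(C)CCN1CCN(c2nc(-c3ccccn3)nc3c2CN(Cc2ccccc2)CC3)CC1` gives 57%; the one measured step, a number 22.6 percentage points higher from compound 1 to compound 3 (beyond the scatter), places 4-(2-(dimethylamino)ethyl)piperazin-1-yl in place of 4-carbamoylpiperidin-1-yl on an aromatic carbon. Compound 2 `CN1CCN(CCCNc2nc(-c3ccccn3)nc3c2CN(Cc2ccccc2)CC3)CC1` stands apart: in this assay compound 2 is reported as "not active" (no number reported), so no number places it against compound 1 or compound 3.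

Compound 4 `CN1CCN(CCCNc2nc(-c3ccncc3)nc3c2CN(Cc2ccccc2)CC3)CC1` differs from compound 2 only in the change (pyridin-4-yl in place of pyridin-2-yl on an aromatic carbon). Among the measured compounds shown here, no measured step bears on this change: the step from compound 1 to compound 3 alters a different group on the core, and no pair among the measured compounds exchanges one pyridinyl for another. The expectation for compound 4 therefore rests on compound 2 alone, which shows no response in this assay, and nothing in the data suggests that this change should open a large response. Compound 4 is thus expected to remain low in this assay, estimated at 15%, within a range of 0% to 40%, with a real chance that it too is reported without a number.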

Compound 4, largest response reached (Emax), in percent of the reference or control that the assay uses: "not active" (no number reported)
Nothing numeric was reported for compound 4; there is nothing to compare the estimate with.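

Compound 2 and compound 4 are both reported as "not active" in this assay, with no number for either, so no step can be read between them. No measurement here offers an explanation for this outcome. The compounds shown leave open whether pyridin-4-yl in place of pyridin-2-yl changes the response on a core that gives a measurable one.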